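Amide side chain change from compound 2 to compound 4

The compounds below may be only part of what the source reports. "The series", "measured", "known", "first", "only" and "open" are said of these compounds alone.

In a functional assay on PC-3 cells (Homo sapiens) for inhibition, read by CellTiter-Glo, with a stated time of 72 h (on this read-out lower numbers stand for higher toxicity in this test and higher numbers for lower toxicity in this test), compound 1 `CC1=C(CC(=O)NCCN(C)C)c2cc(F)ccc2/C1=C\c1nc2ccccc2s1` gives 4880 nM and compound 2 `CC1=C(CC(=O)N(C)CCN(C)C)c2cc(F)ccc2/C1=C\c1nc2ccccc2s1` gives 5880 nM, so compound 2 stands level with compound 1. Compound 3 `CC1=C(CC(=O)NCCN(C)C)c2cc(F)ccc2/C1=C\c1ccc(S(C)(=O)=O)cc1` gives only a limit of the assay, > 50000 nM. The large step of an at least 10-fold higher number from compound 1 to compound 3 (1.01 log units; beyond the scatter) concerns the other end of the molecule and does not bear on this change. Compound 4 `CC1=C(CC(=O)NCCN2CCCC2)c2cc(F)ccc2/C1=C\c1nc2ccccc2s1` differs from compound 2 on the carbonyl carbon: (2-(pyrrolidin-1-yl)ethyl)amino in place of (2-(dimethylamino)ethyl)(methyl)amino on a carbonyl carbon. The closest evidence is a 1.2-fold higher number from compound 1 to compound 2 (0.08 log units; within the scatter), within the scatter and confined to the amide nitrogen. Going by the values given here, no measured step covers the pyrrolidine ring. In this assay the expected step, nothing beyond the scatter, is a 1.2-fold lower number from compound 2 to compound 4 (0.09 log units; within the scatter). The estimate for compound 4 is 4800 nM, expected within 2200 nM to 11000 nM.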

Compound 4, half-maximal cytotoxic concentration: 4940 nM
Estimate against measurement, compound 4: 1.0-fold (0.01 log units) below; the range from low to high includes it.
By their numbers in this assay, from the lowest: compounds 1, 4 and 2 (each within the scatter of the next). At a limit, above all of these: compound 3.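

In this assay, (2-(pyrrolidin-1-yl)ethyl)amino in place of (2-(dimethylamino)ethyl)(methyl)amino on the carbonyl carbon stays within the scatter (a 1.2-fold lower number from compound 2 to compound 4 (0.08 log units; within the scatter)). Pyrrolidin-1-yl in place of dimethylamino alone also stays within the scatter (a 1.0-fold higher number from compound 1 to compound 4 (0.01 log units; within the scatter)), so compounds 1, 2 and 4 show that a ring at this amine, and not only open-chain methyl groups, leaves the read-out level. Nothing shown gives a cause for these steps.

Open, as far as these compounds go, is whether a morpholine ring or a carboxylic acid in place of pyrrolidin-1-yl, or a longer chain carrying it, would also stay within the scatter.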